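A few compounds are considered here, and "the series" means these few. Any claim that something is new, unique, unknown or untested is made for them only; others in the source may bear on it.

Measured compounds:
Compound 1, `CN(C(=O)NC(=O)c1ccc(F)c(F)c1)c1nc(C(F)(F)F)c(C(=O)N/N=C/c2cc(C(F)(F)F)cc(C(F)(F)F)c2)s1`: in a functional assay on A549 cells (Homo sapiens) for inhibition, read by MTT assay, with a stated time of 72 h (a higher number here means a weaker inhibitor, a lower number a stronger inhibitor), compound 1 gives 5.47 ug/mL.
Compound 2, `CN(C(=O)NC(=O)c1ccc(Cl)cc1Cl)c1nc(C(F)(F)F)c(C(=O)N/N=C/c2cc(C(F)(F)F)cc(C(F)(F)F)c2)s1`: in this assay compound 2 gives > 100 ug/mL, which is a limit of the assay and not a number.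

Compound 2 thus stands at the weak end of what is known, with only a limit recorded for it (the limit of > 100 ug/mL in this assay, at which 1 of the 2 values shown sits). Compound 3, `CN(C(=O)NC(=O)c1cccc(C(F)(F)F)c1)c1nc(C(F)(F)F)c(C(=O)N/N=C/c2cc(C(F)(F)F)cc(C(F)(F)F)c2)s1`, has not yet been measured; it differs from compound 2 by 3-(trifluoromethyl)phenyl in place of 2,4-dichlorophenyl on a carbonyl carbon. For the measured compounds named here, only one measured step touches this position: an at least 18-fold higher number from compound 1 to compound 2 (1.26 log units; beyond the scatter), a large step that shows the aryl group on this carbonyl carbon can move the number strongly. The two measured compounds mark only the two ends, and nothing shows where the 3-(trifluoromethyl)phenyl group falls between them. An intermediate number is therefore expected, with a real chance that the assay again reports only a limit. Compound 3 is expected to give 30 ug/mL, within 8 ug/mL to 100 ug/mL. The estimated step of an at least 3.3-fold lower number from compound 2 to compound 3 (0.52 log units; beyond the scatter) is expected to run toward a lower number.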

Compound 3, half-maximal inhibitory concentration: 8.2 ug/mL
Beside the measured number, compound 3's estimate is 3.7-fold (0.56 log units) above it, and the stated range covers the measured number.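

In this assay, putting 3-(trifluoromethyl)phenyl in place of 2,4-dichlorophenyl gives an at least 12-fold lower number from compound 2 to compound 3 (1.08 log units; beyond the scatter), so the loss seen with compound 2 is not shared by every substituted phenyl group on this carbonyl carbon. Exchanging 3,4-difluorophenyl for 3-(trifluoromethyl)phenyl gives a 1.5-fold higher number from compound 1 to compound 3 (0.18 log units; within the scatter), so these two different groups cannot be told apart here. Compound 2 remains the only one of the three recorded as a limit and not a number: the limit of > 100 ug/mL in this assay, at which 1 of the 3 values shown sits.

The compounds shown do not separate the presence of chlorine atoms from where they sit on the ring, a question that a 3,4-dichlorophenyl group would bear on. They also leave open what happens on this carbonyl carbon with a cyclohexyl group, or with a phenyl ring carrying an amine or a carboxylic acid.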